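The source may hold more compounds than are shown below. What is called first, only, known or untested is meant among the compounds shown, and "the series" means these compounds.

Measured in an ADME assay on microsomes from liver (Rattus norvegicus) for metabolic stability, read by LC-MS, using NADPH, with a stated time of 10 min, tested at 0.1 uM; a lower number here means slower removal, a higher number faster removal of the compound:
- compound 1 `COc1ccc(F)cc1N1C(=O)CSC1c1cccc(C(=O)NCCCCn2cccn2)c1`: 1470 mL.min-1.g-1
- compound 2 `Cc1cccc(N2C(=O)CSC2c2cccc(C(=O)NCCCCc3ccccc3)c2)c1`: 3140 mL.min-1.g-1

Compound 2 carries the higher of the two numbers, and its gap to compound 1 lies beyond the scatter. Compound 3 `O=C(NCCCCc1ccccc1)c1cccc(C2SCC(=O)N2c2cccc(F)c2)c1` differs from compound 2 by fluoro in place of methyl on an aromatic carbon, meta to a large group. Among the measured compounds shown here, no measured pair differs in one place, so nothing sizes this change directly. In this assay a small fall is expected, within the scatter, an estimated 1.4-fold lower number from compound 2 to compound 3 (0.15 log units; within the scatter). The estimate for compound 3 is 2200 mL.min-1.g-1, with an expected range of 1000 mL.min-1.g-1 to 4500 mL.min-1.g-1.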

Compound 3, intrinsic clearance in microsomes: 3240 mL.min-1.g-1
Beside the measured number, compound 3's estimate is 1.5-fold (0.17 log units) below it; the range from low to high includes it.
By their numbers in this assay, from the lowest: compound 1; then compounds 2 and 3 (each within the scatter of the next).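

In this assay, among the compounds shown here, the first one-place step, 3-methylphenyl to 3-fluorophenyl, gives a 1.0-fold higher number from compound 2 to compound 3 (0.01 log units; within the scatter) and so stays within the scatter. At this position, meta to a large group, the read-out therefore does not separate fluoro from methyl, at least on the chain shared by compound 2 and compound 3.

On these data alone, whether a trifluoromethyl, a methoxy or an amine at the same place would also leave the read-out unmoved remains open. Compound 1 differs from compound 2 in more than one place, so its gap cannot be assigned to either part of the structure. No measurement at hand accounts for the result of this change.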